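The compounds below may be only part of what the source reports. "The series", "measured", "known", "first", "only" and "open" are said of these compounds alone.

Two compounds share one core and differ only in the group attached to one aromatic carbon of that core. Compound 1 `CC(C)(C)c1ccc(Oc2ccc3c(NCCCNCc4ccco4)ccnc3c2)cc1` and compound 2 `c1ccc(CCc2ccc3c(NCCCNCc4ccco4)ccnc3c2)cc1` were both tested in a physicochemical assay for acid dissociation. In this assay compound 1 gives 9.28. In this assay compound 2 gives 9.47. The two numbers lie within the usual scatter of each other, so neither compound can be said to give up its proton more or less readily than the other.

Compound 3 `CN(C)c1cccc(Oc2ccc3c(NCCCNCc4ccco4)ccnc3c2)c1` has not yet been measured. It differs from compound 2 in one place: 3-(dimethylamino)phenoxy in place of phenethyl on an aromatic carbon. Going by the values given here, no step between two measured compounds covers this exact exchange. What the measured pair does show is that swapping the group on this aromatic carbon left the number within the scatter, and the 3-(dimethylamino)phenoxy group of compound 3 is closer in make-up to the group carried by compound 1, whose value in this assay is 9.28, than to the phenethyl group of compound 2. The expected step, a number 0.17 log units lower from compound 2 to compound 3 (within the scatter), is therefore small, within the scatter or barely beyond it, and downward if anything. Compound 3 is expected to give 9.3 in this assay, with a range from 9 to 9.6.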

Compound 3, acid dissociation constant: 9.28
The estimate for compound 3 lay 0.02 log units above the measured number; measured number inside the range.
By their numbers in this assay, from the lowest: compounds 1, 3 and 2 (each within the scatter of the next).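

In this assay, putting 3-(dimethylamino)phenoxy on this aromatic carbon in place of phenethyl gives a number 0.19 log units lower from compound 2 to compound 3 (within the scatter). Keeping the oxygen and exchanging the 4-(tert-butyl)phenyl on it for 3-(dimethylamino)phenyl gives no change at the digits printed from compound 1 to compound 3 (within the scatter), a comparison the first two compounds could not offer, since they differ in both the link to the core and the rest of the group. Across these three compounds, then, no step leaves the scatter, even with a group that brings in nitrogen and hydrogen-bond acceptors where phenethyl has none.

As far as these compounds go, all three groups contain one six-membered aromatic ring of carbon only, so it remains open whether a group without such a ring, such as a carboxylic acid or a short chain ending in an amine, would also stay within the scatter on this aromatic carbon. Nothing available offers a measured explanation for why these numbers lie so close together.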